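Cyano to Carbamoyl on the Shared Core

A few compounds are considered here, and "the series" means these few. Any claim that something is new, unique, unknown or untested is made for them only; others in the source may bear on it.

Compound 1 `COc1ccc2c(c1)OC(c1cc(OC)c(OC)c(OC)c1)C(C(=O)N(C)OC)=C2`: 11700 nM
Compound 2 `COc1ccc2c(c1)OC(c1cc(OC)c(OC)c(OC)c1)C(/C=N/O)=C2`: 14100 nM
Compound 3 `COc1ccc2c(c1)OC(c1cc(OC)c(OC)c(OC)c1)C(C#N)=C2`: 3400 nM

In a functional assay for inhibition of nuclear factor NF-kappa-B complex (Homo sapiens) (a lower number here means a stronger inhibitor, a higher number a weaker inhibitor), compound 3 gives the lowest of the three numbers. Its nearest neighbour is compound 1, which in this assay gives 11700 nM, and the step of a 3.4-fold lower number from compound 1 to compound 3 (0.54 log units; beyond the scatter) is modest and beyond the scatter. The step of a 4.1-fold lower number from compound 2 to compound 3 (0.62 log units; beyond the scatter) is of similar size. Compound 4 `COc1ccc2c(c1)OC(c1cc(OC)c(OC)c(OC)c1)C(C(N)=O)=C2` differs from compound 3 in one place: carbamoyl in place of cyano on a double-bonded ring carbon. Both measured steps onto compound 3 replaced a larger group on that carbon with the cyano group and lowered the number; the carbamoyl group enters as a group larger than cyano, closer in size to the oxime of compound 2. The two steps of a 3.4-fold lower number from compound 1 to compound 3 (0.54 log units; beyond the scatter) and a 4.1-fold lower number from compound 2 to compound 3 (0.62 log units; beyond the scatter) therefore bear on this change, and a modest rise is expected. For compound 4 the estimated step is a 2.4-fold higher number from compound 3 to compound 4 (0.37 log units; beyond the scatter), giving an expected value of 8000 nM with a range from 3000 nM to 25000 nM.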

Compound 4, half-maximal inhibitory concentration: > 50000 nM
Compound 4 was reported as a limit; the forecaster's own chance of this, stated with the estimate: 5%; middle value at least 6.2-fold (0.79 log units) from the limit.
By their numbers in this assay, from the lowest: compound 3; then compounds 1 and 2 (each within the scatter of the next). At a limit, above all of these: compound 4.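

The value of compound 4 in this assay is a limit of the assay and not a number: the limit of > 50000 nM in this assay, at which 1 of the 4 values shown sits. Within the data shown here, on this double-bonded ring carbon, carbamoyl in place of cyano gives an at least 14-fold higher number from compound 3 to compound 4 (1.16 log units; beyond the scatter), a large step and not the modest rise that the earlier steps onto compound 3 suggested. The other two steps, an at least 3.5-fold higher number from compound 2 to compound 4 (0.54 log units; beyond the scatter) and an at least 4.2-fold higher number from compound 1 to compound 4 (0.63 log units; beyond the scatter), show that heavy-atom count alone does not order these groups, since compound 4 stands apart from compound 2 at an equal count and compound 1 carries the largest group without reaching that limit.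

As far as these compounds go, how far beyond its limit compound 4 lies stays open. Also open, from the compounds shown here alone, is whether a methylamide, a carboxylic acid or an aminomethyl group on this carbon would sit nearer compound 3 or compound 4.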